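The compounds below may be only part of what the source reports. "The series", "measured", "known", "first", "only" and "open" are said of these compounds alone.

Of the compounds shown here, three with the same core have been measured in a physicochemical assay for solubility, read by HPLC, in phosphate buffer, with a stated time of 24 h, at 20 degrees C, at pH 7.4; on this read-out lower numbers stand for lower solubility and higher numbers for higher solubility. Compound 1 `CC(=O)N1CC(CC(=O)NO)(NS(=O)(=O)c2ccc(OCc3cc(C)nc4ccccc34)cc2)C1` carries an acetyl group on the amine nitrogen of its four-membered ring. In this assay compound 1 reaches only the limit of < 500 nM, a boundary of the method rather than a number. Compound 2 `CC(=O)N1CC2(C1)CC(NS(=O)(=O)c1ccc(OCc3cc(C)nc4ccccc34)cc1)(C(=O)NO)C2` gives 84000 nM in this assay. Compound 3 `CCCCN1CC(CC(=O)NO)(NS(=O)(=O)c2ccc(OCc3cc(C)nc4ccccc34)cc2)C1`, which carries a butyl chain on that ring nitrogen, gives 70000 nM in this assay. The number for compound 3 sits within the scatter of the number for compound 2, so the two cannot be ordered. Going by the values given here, the one step that can be measured, an at least 140-fold higher number from compound 1 to compound 3 (2.14 log units; beyond the scatter), is the only direct guide to the ring nitrogen.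

Compound 4 `Cc1cc(COc2ccc(S(=O)(=O)NC3(CC(=O)NO)CN(C(=O)N4CCCCC4)C3)cc2)c2ccccc2n1` has not yet been measured. It differs from compound 3 in one place: (piperidin-1-yl)carbonyl in place of butyl on an amine nitrogen in a ring. Among the compounds with values here, the entering group, like the acetyl of compound 1, is joined through a carbonyl, whereas the butyl of compound 3 is a plain chain, so the one measured step bears on this change in reverse and was large. The number for compound 4 is therefore expected to fall, by an estimated 7.0-fold lower number from compound 3 to compound 4 (0.85 log units; beyond the scatter), a smaller step than the full measured one. The estimate for compound 4 in this assay is 10000 nM, with a range from 1000 nM to 50000 nM.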

Compound 4, solubility: 80000 nM
The estimate for compound 4 lay 8.0-fold (0.90 log units) below the measured number; measured number above the stated range.
By their numbers in this assay, from the lowest: compounds 3, 4 and 2 (each within the scatter of the next). At a limit, below all of these: compound 1.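

In this assay, (piperidin-1-yl)carbonyl in place of butyl on the amine nitrogen of the four-membered ring gives a 1.1-fold higher number from compound 3 to compound 4 (0.06 log units; within the scatter), so the two groups cannot be told apart here, although the entering group brings a six-membered ring, a carbonyl and more heavy atoms. Piperidin-1-yl in place of methyl on the carbonyl carbon gives an at least 160-fold higher number from compound 1 to compound 4 (2.20 log units; beyond the scatter), so a carbonyl on this nitrogen does not by itself go with a low number: compound 1 has one and sits at the bottom, while compound 4 has one and does not, which makes what the carbonyl carries the part that matters among these compounds. The size of that step is only a bound, as the value of compound 1 is a limit and not a number: the limit of < 500 nM in this assay, at which 1 of the 4 values shown sits.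

The compounds shown leave open how much of the group on the carbonyl is needed, since nothing stands in the gap left by methyl and piperidin-1-yl, such as an ethyl or a propyl chain. They also leave open whether a carbonyl carrying morpholin-4-yl, or a ring nitrogen with only a hydrogen on it, would fit with these numbers.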